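Swapping an oxygenated saturated ring for phenyl on the thioether

A few compounds are considered here, and "the series" means these few. Any claim that something is new, unique, unknown or untested is made for them only; others in the source may bear on it.

Measured so far:
- Compound 1 `CC1=CC(=O)OC(CSc2nc(-c3ccc(C)cc3)c(-c3ccc(C)cc3)[nH]2)C1` gives 280 nM in an assay on microsomes from liver for inhibition of sterol O-acyltransferase 1 (Rattus norvegicus); on this read-out lower numbers stand for stronger inhibition and higher numbers for weaker inhibition.
- Compound 2 `CO[C@H]1C[C@H](O)C[C@@H](CSc2nc(-c3ccccc3)c(-c3ccccc3)[nH]2)O1` gives 90 nM in this assay.

Both compounds carry the same thioether-linked core, and of the two numbers compound 2 holds the lower one; its gap to compound 1 lies beyond the usual scatter of repeated measurements. The two compounds differ in more than one place, so no single structural step can be read from that pair.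

Compound 3 `c1ccc(CSc2nc(-c3ccccc3)c(-c3ccccc3)[nH]2)cc1` has not yet been measured. It differs from compound 2 in one place: a group of 6 heavy atoms (6 carbon; one six-membered aromatic ring of carbon only) in place of a group of 9 heavy atoms (6 carbon, 3 oxygen; one six-membered non-aromatic ring with 1 hetero atom), on a saturated chain carbon bound to a sulfur. Going by the values given here, nothing among the measured compounds shows what this kind of exchange does on its own, so the size of the step is uncertain. The expectation is a step toward a higher number in this assay, of about a 4.4-fold higher number from compound 2 to compound 3 (0.65 log units; beyond the scatter), larger than the scatter but not dramatic. For compound 3 the estimated value in this assay is 400 nM, with a range from 100 nM to 2000 nM.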

Compound 3, half-maximal inhibitory concentration: 290 nM
Compound 3: the middle estimate sits 1.4-fold (0.14 log units) above what was measured; low and high end bracket the measured number.
By their numbers in this assay, from the lowest: compound 2; then compounds 1 and 3 (each within the scatter of the next).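

In this assay, going by these compounds alone, replacing the oxygen-bearing six-membered non-aromatic ring with phenyl, on a saturated chain carbon bound to a sulfur, gives a 3.2-fold higher number from compound 2 to compound 3 (0.51 log units; beyond the scatter) and is the only single-place step available here. This shows that the group at this position affects the read-out: the group with 1 hydrogen-bond donor, 3 hydrogen-bond acceptors and 3 defined stereocentres goes with the lower number, and phenyl, which has no donors or acceptors, goes with the higher one, although the step is modest rather than dramatic. No measurement shown here explains why the step runs in this direction.

Because the exchange changes several features at once, this one pair cannot separate the contributions of the oxygen atoms, the defined stereocentres and the loss of the aromatic ring. The compounds shown also leave open how a cyclohexyl ring, a tetrahydropyran ring with no further oxygen groups, a pyridine ring or an amine would behave on the same chain carbon, so no trend can yet be drawn for this position.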